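The compounds below may be only part of what the source reports. "The series", "measured", "known", "first", "only" and "open" are said of these compounds alone.

Working notes on the series: in a toxicity assay on THP-1 cells (Homo sapiens) for inhibition (on this read-out higher numbers stand for lower toxicity in this test and lower numbers for higher toxicity in this test), only limits are available so far, and no exact number has been obtained. Compound 1 `Cn1c(-c2ccccc2)cnc1NC(=O)c1ccc(F)cc1` gives > 100000 nM as a limit of the assay. Compound 2 `COc1ccc(-c2cnc(NC(=O)c3cccc(Cl)c3)n2C)cc1` gives > 28000 nM as a limit of the assay, and this limit is all that is known of where it stands. Going by the values given here, no measured step connects these two compounds, so the size of a single change cannot be read from the data.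

Compound 3 `COc1ccc(-c2cnc(NC(=O)c3ccc(F)cc3)n2C)cc1` differs from compound 2 in one place. The difference is 4-fluorophenyl in place of 3-chlorophenyl on a carbonyl carbon and consists of 4-fluorophenyl in place of 3-chlorophenyl on a carbonyl carbon. Compound 1 carries the same 4-fluorophenyl on its carbonyl carbon and also returned > 100000 nM as a limit, which supports the expectation below.

The expected change is a step that the limit leaves unreadable from compound 2 to compound 3 and no step beyond the scatter is foreseen in this assay for this swap. In this assay compound 3 is expected at 50000 nM with an estimated range from 20000 nM to 120000 nM and a good chance of only a limit.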

Compound 3, half-maximal cytotoxic concentration: >= 50000 nM
Compound 3 ended at the assay's limit (the forecaster's own chance of this, stated with the estimate: 80%); the middle value lies on the limit itself.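

In this assay compound 1, compound 2 and compound 3 all stand as limits of the assay, and no step can be read from compound 2 to compound 3 or from compound 1 to compound 3. Still open, as far as these compounds go, is whether 4-fluorophenyl in place of 3-chlorophenyl on a carbonyl carbon, or methoxy in place of hydrogen on an aromatic carbon, changes the read-out at all.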